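This account rests on a few compounds, and the source may have more. Where it says the series, first, only, none or still open, it means among the compounds named here.

In an ADME assay on microsomes from liver (Rattus norvegicus) for metabolic stability, read by LC-MS, with a stated time of 10 min, tested at 0.5 uM (a lower number here means that less of the compound is left, a higher number that more of the compound is left), compound 1 `c1cnc(CN(CCCN2CCNCC2)[C@H]2CCCc3cccnc32)nc1` gives 68%, compound 2 `c1cnc2c(c1)CCC[C@@H]2N(CCCN1CCNCC1)Cc1nc2ccccc2s1` gives 21% and compound 3 `CC(C)N1CCN(CCCN(C[C@H]2Cc3ccccc3CN2)[C@H]2CCCc3cccnc32)CC1` gives 4%, the lowest of the three. Among the measured compounds shown here, the one step measured so far, a number 47 percentage points lower from compound 1 to compound 2 (beyond the scatter), concerns a group sitting on a saturated chain carbon bound to an amine nitrogen, a different part of the molecule. Compound 4 `c1ccc2c(c1)CN[C@@H](CN(CC[C@@H]1CCCNC1)[C@H]1CCCc3cccnc31)C2` differs from compound 3 at another place: piperidin-3-yl in place of (4-isopropylpiperazin-1-yl)methyl on a saturated chain carbon, two bonds along the chain from an amine nitrogen. For the measured compounds named here, no measured step touches this part of the chain, so the data give no direction for the change, and the result for compound 4 is expected to lie near the low end seen so far, with a step of a number 11 percentage points higher from compound 3 to compound 4 (beyond the scatter) estimated. Compound 4 is therefore estimated at 15%, expected between 3% and 40%.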

Compound 4, percent of the compound remaining: 28%
Compound 4: the middle estimate sits 13 percentage points below what was measured; the measured number falls inside the stated range.
By their numbers in this assay, from the lowest: compound 3; then compounds 2 and 4 (each within the scatter of the next); then compound 1.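

Among the compounds shown here, this is the first measured change at this part of the chain, and it shows that the group here matters: in this assay, a number 24 percentage points higher from compound 3 to compound 4 (beyond the scatter). The smaller piperidin-3-yl group therefore leaves more of the compound than the (4-isopropylpiperazin-1-yl)methyl group it replaces. No measurement at hand explains this rise. The swap alters the ring, the isopropyl group and the chain length together, so the compounds shown leave open which of these accounts for the step. A piperazin-1-ylmethyl group without the isopropyl would help separate them.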